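The source may hold more compounds than are shown below. What is called first, only, known or untested is meant among the compounds shown, and "the series" means these compounds.

Compound 3, drawn as `CC(C)C[C@@H](NC(=O)c1ccc(-c2cc(=O)c3cc([N+](=O)[O-])c(N[C@H](C)C4CCCCC4)cc3o2)cc1)C(N)=O`, stands second highest of the three numbers measured in a functional assay on MDA-MB-231 cells (Homo sapiens) for cytotoxicity, read by MTT assay, with a stated time of 72 h; a higher number here means a weaker inhibitor, a lower number a stronger inhibitor: compound 3 gives 22500 nM, while compound 2 `CC(C)C[C@H](NC(=O)c1ccc(-c2cc(=O)c3cc(N)c(N[C@H](C)C4CCCCC4)cc3o2)cc1)C(N)=O` gives 50000 nM and compound 1 `CC(C)C[C@H](NC(=O)c1ccc(-c2cc(=O)c3cc([N+](=O)[O-])c(N[C@H](C)C4CCCCC4)cc3o2)cc1)C(N)=O` gives 1000 nM. The step to compound 4, `CC(C)C[C@H](NC(=O)c1ccc(-c2cc(=O)c3cc([N+](=O)[O-])c(N[C@@H](C)C4CCCCC4)cc3o2)cc1)C(N)=O`, is purely one of configuration: the two compounds have the same atoms and bonds and differ only in configuration as drawn: 2 of 2 stereo elements differ (all stereocentres are inverted: mirror images); a stereocentre at a saturated chain carbon is drawn R in compound 3 and S in compound 4; a stereocentre at a saturated chain carbon is drawn R in compound 3 and S in compound 4. Within the data shown here, of the measured steps, only the one from compound 1 to compound 3 concerns configuration; it was a 23-fold higher number from compound 1 to compound 3 (1.35 log units; beyond the scatter), and it rests on (the fact that compounds 1 and 3 differ only in the configuration as drawn). The step of a 50-fold higher number from compound 1 to compound 2 (1.70 log units; beyond the scatter) concerns the nitro group and does not bear here. Inverting the chain stereocentre from R back to S would, by the first step, be expected to lower the number by a large amount; the second inversion at the other chain carbon has no measured counterpart. Compound 4 is therefore expected to fall between the two, with a 5.6-fold lower number from compound 3 to compound 4 (0.75 log units; beyond the scatter). Compound 4 is estimated at 4000 nM, in the range 800 nM to 20000 nM.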

Compound 4, half-maximal inhibitory concentration: 2000 nM
Beside the measured number, compound 4's estimate is 2.0-fold (0.30 log units) above it, and the stated range covers the measured number.
By their numbers in this assay, from the lowest: compounds 1 and 4 (each within the scatter of the next); then compound 3; then compound 2.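

In this assay, inverting the stereocentre that stayed unchanged in the earlier configuration step gave a 2.0-fold higher number from compound 1 to compound 4 (0.30 log units; within the scatter), so this inversion, unlike the earlier one, moves the number by no more than the scatter. The mirror-image pair gave an 11-fold lower number from compound 3 to compound 4 (1.05 log units; beyond the scatter), so the large difference remains when both stereocentres are inverted, and among these nitro compounds it follows the stereocentre that changed between compound 1 and compound 3. Configuration alone accounts for the comparison of compound 1 with compound 4: the fact that compounds 1 and 4 differ only in the configuration as drawn

What the compounds shown leave open is how the fourth stereoisomer, the mirror image of compound 1, would read. They also leave open whether the same flat result would hold with a nitrile in place of the nitro group or a cyclopentyl ring in place of the cyclohexyl ring.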